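Aminoindazole ureas: benzyl to butoxy on the aryl amide

This account rests on a few compounds, and the source may have more. Where it says the series, first, only, none or still open, it means among the compounds named here.

Measured compounds:
compound 1 `Nc1nn(C(=O)Nc2ccc(Cc3ccccc3)cc2)c2ccccc12` — 1860 nM
compound 2 `COc1ccccc1NC(=O)n1nc(N)c2ccccc21` — 86000 nM

Two compounds share the core of compound 1 and differ only in the aryl group on the urea nitrogen. In a functional assay on RPMI-8226 cells (Homo sapiens) for inhibition, read by sulforhodamine B assay, with a stated time of 48 h (on this read-out lower numbers stand for stronger inhibition of growth and higher numbers for weaker inhibition of growth), compound 1 gives 1860 nM, the lowest of the two numbers. In this assay, going by the values given here, compound 2 gives 86000 nM, a much higher number, well beyond the scatter; no single-point step between the two is defined, so the two values only show that the aryl substituent has a large bearing on the read-out.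

Compound 3 `CCCCOc1ccc(NC(=O)n2nc(N)c3ccccc32)cc1` is the next member. Against compound 1 the change is butoxy in place of benzyl on an aromatic carbon. Among the compounds with values here, no measured pair isolates a change of this kind, so the size of the step cannot be read from the data. Butoxy keeps a chain of comparable reach in the same place while removing the ring, so a moderate loss is expected rather than a gain. The step from compound 1 to compound 3 is expected to be a 2.7-fold higher number from compound 1 to compound 3 (0.43 log units; beyond the scatter). For compound 3 the estimate in this assay is 5000 nM, within 1500 nM to 20000 nM.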

Compound 3, concentration for 50% growth inhibition: 2720 nM
Compound 3: the middle estimate sits 1.8-fold (0.26 log units) above what was measured; the measured number falls inside the stated range.
By their numbers in this assay, from the lowest: compounds 1 and 3 (each within the scatter of the next); then compound 2.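

In this assay the exchange of benzyl for butoxy on an aromatic carbon, para to a large group, gives a 1.5-fold higher number from compound 1 to compound 3 (0.17 log units; within the scatter) and so does not separate the two groups on this read-out. Going by these compounds alone, this is the first step defined at this position, and it shows that the six-membered aromatic ring of carbon only can leave, with 7 heavy atoms giving way to 5 and a hydrogen-bond acceptor entering, without a change beyond the scatter. Nothing on hand explains why the value holds across this exchange.

Still open, as far as these compounds go, is how far this tolerance extends: a longer chain such as hexyloxy, a chain ending in a carboxylic acid or an amine, or a bare hydrogen at the same place could each test whether the read-out depends on the reach of the group at all. Within the data shown here, the much higher number of compound 2 also remains untied to any single change, as no one-place step links it to compound 1 or compound 3, so the roles of the group's size and its place on the aryl ring stay unresolved.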